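The source may report more compounds than this note shows. Statements on the series, on what has been measured and on what is new or still open speak of the compounds shown alone.

Compound 1, `Cc1nn(C)c(Oc2ccc(Cl)cc2)c1/C=N\CCCCCOc1cc2oc(=O)cc(C)c2cc1Cl`, and compound 2, `Cc1nn(C)c(Oc2cccc(F)c2)c1/C=N\CCCCCCOc1cc2oc(=O)cc(C)c2cc1Cl`, share the same core and differ in the ring hanging from it and in the chain that joins the two halves. In a functional assay on HepG2 cells (Homo sapiens) for antiproliferative activity, read by MTT assay, with a stated time of 72 h (a higher number here means a weaker inhibitor, a lower number a stronger inhibitor), compound 1 gives 15300 nM. Compound 2 in this assay gives > 25000 nM, which is a limit of the assay rather than a number. Compound 2 therefore stands at the limit of > 25000 nM in this assay, at which 1 of the 2 values shown sits, and nothing sharper can be said of where it lies. Compound 3, `Cc1nn(C)c(Oc2ccc(F)c(F)c2)c1/C=N\CCCCCCOc1cc2oc(=O)cc(C)c2cc1Cl`, has not yet been measured. It differs from compound 2 by fluoro in place of hydrogen on an aromatic carbon. No measured pair differs in exactly this way, so the size of the step cannot be read from the numbers shown, and because compound 2 already sits at the limit of > 25000 nM in this assay, at which 1 of the 2 values shown sits, any estimate rests on a limit. The expected step that the limit leaves unreadable from compound 2 to compound 3 is assumed to stay within the scatter, in no particular direction. Compound 3 is accordingly expected to give about 28000 nM, with a likely range from 10000 nM to 70000 nM.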

Compound 3, half-maximal inhibitory concentration: > 25000 nM
Compound 3 was reported as a limit (the forecaster's own chance of this, stated with the estimate: 60%); the middle value lies beyond the limit too.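

Compound 2 and compound 3 are both reported only as limits of this assay, so no step from one to the other can be read: the limit of > 25000 nM in this assay, at which 2 of the 3 values shown sit.

From the compounds shown here alone, whether fluoro in place of hydrogen on the aromatic ring changes the activity at all stays open, as does how far past the limit either compound truly lies.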